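Microsomal half-life on extending the amine tail

The compounds below may be only part of what the source reports. "The series", "measured", "known", "first", "only" and "open" are said of these compounds alone.

Three measured compounds share one core and differ only at the saturated chain carbon bound to the amine nitrogen. Compound 1 `CC(C)N1C(=O)C(=O)N=C1/N=C(\NCC(C)(C)C)Nc1ccc(Cl)c(Cl)c1` carries tert-butyl there, compound 2 `CC(C)N1C(=O)C(=O)N=C1/N=C(\NCc1ccccc1)Nc1ccc(Cl)c(Cl)c1` phenyl, and compound 3 `CC(C)N1C(=O)C(=O)N=C1/N=C(\NCCN(C)C)Nc1ccc(Cl)c(Cl)c1` (dimethylamino)methyl. In an in vitro ADME assay on microsomes from liver (Homo sapiens) for metabolic stability, read by LC-MS (a lower number here means that the compound disappears faster, a higher number that the compound lasts longer), compound 1 gives > 1 h, which is a limit of the assay. In this assay compound 2 gives > 1 h, also a limit. In this assay compound 3 gives > 1 h, again a limit. The steps between them are therefore not readable: a step that the two limits leave unreadable from compound 1 to compound 2, a step that the two limits leave unreadable from compound 1 to compound 3, a step that the two limits leave unreadable from compound 2 to compound 3. Compound 3 thus stands where every measured value of the series sits, namely (the limit of > 1 h in this assay, at which 3 of the 3 values shown sit). Compound 4 `CC(C)N1C(=O)C(=O)N=C1/N=C(\NCCCCN1CCCC1)Nc1ccc(Cl)c(Cl)c1` is not yet measured and differs from compound 3 in that (2-(pyrrolidin-1-yl)ethyl in place of dimethylamino on a saturated chain carbon, two bonds along the chain from an amine nitrogen). Among the measured compounds shown here, none of the measured steps bears a readable size on this change. No direction beyond the scatter is expected for a step that the limit leaves unreadable from compound 3 to compound 4, and the most likely outcome is another limit. For compound 4 the estimate in this assay is 1.5 h, with a range from 0.5 h to 4 h.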

Compound 4, half-life: > 1 h
Compound 4: only a limit was reported (the forecaster's own chance of this, stated with the estimate: 70%); the middle value does not contradict the limit.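

No new step can be read from compound 4 to compound 1, compound 2 or compound 3 in this assay, because all the values sit at one limit: the limit of > 1 h in this assay, at which 4 of the 4 values shown sit.

The compounds shown leave open how the half-lives of these four compounds compare, and so whether the amine tail changes it at all.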